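The source may hold more compounds than are shown below. What is called first, only, known or untested is meant among the compounds shown, and "the series" means these compounds.

Measured in a functional assay on NCI-H1299 cells (Homo sapiens) for inhibition, read by CCK-8 assay, with a stated time of 72 h, tested at 1 uM; a higher number here means a stronger effect of the compound at the concentration tested, a lower number a weaker effect:
compound 1 `CN(C)C(=O)c1cc2cnc(Nc3ccc(C(=O)NCCCCN=C=S)cc3)nc2n1C1CCCC1` gives 55.2%
compound 2 `CN(C)C(=O)c1cc2cnc(Nc3ccc(C(=O)NCCCCN=C=S)cc3F)nc2n1C1CCCC1` gives 28.7%
compound 3 `CN(C)C(=O)c1cc2cnc(Nc3ccc(C(=O)NCCCCN=C=S)cc3O)nc2n1C1CCCC1` gives 10.7%

Compound 1 stands highest of the three. Its nearest neighbour is compound 2, with a number 26.5 percentage points lower from compound 1 to compound 2 (beyond the scatter); its furthest is compound 3, with a number 44.5 percentage points lower from compound 1 to compound 3 (beyond the scatter). Between the two lower compounds there is a number 18 percentage points lower from compound 2 to compound 3 (beyond the scatter). Each of these steps changes a single position on the six-membered carbon ring that carries the long group, and each lowers the number beyond the scatter.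

Compound 4 `CN(C)C(=O)c1cc2cnc(Nc3ccc(N=C=S)cc3)nc2n1C1CCCC1` changes the same ring in a different way: a group of 3 heavy atoms (1 carbon, 1 nitrogen, 1 sulfur; no ring) in place of a group of 10 heavy atoms (6 carbon, 2 nitrogen, 1 oxygen, 1 sulfur; no ring), on an aromatic carbon. The long group is cut back, and the small group of three heavy atoms sits directly on the aromatic carbon.

Within the data shown here, none of the measured steps tests this kind of change, so no step bears on it directly. The measured steps only show that this ring is sensitive to alteration, and that every alteration tried so far lowered the number. On that basis a downward step of moderate size is expected, a number 15.2 percentage points lower from compound 1 to compound 4 (beyond the scatter), and compound 4 is estimated at 40%, within a range of 10% to 70%.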

Compound 4, a percentage reported as inhibition, at one concentration (the size of the read-out at that concentration, not a potency): 46.9%
Compound 4: the middle estimate sits 6.9 percentage points below what was measured; low and high end bracket the measured number.
By their numbers in this assay, from the lowest: compound 3; then compound 2; then compounds 4 and 1 (each within the scatter of the next).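

Replacing the group of 10 heavy atoms with the group of 3 heavy atoms gives a number 8.3 percentage points lower from compound 1 to compound 4 (within the scatter) in this assay, so most of the long group can go from this aromatic carbon without a change that stands out from the scatter. The ring is therefore not sensitive to every alteration: this large cut stays within the scatter, while the much smaller fluoro and hydroxy replacements give a number 26.5 percentage points lower from compound 1 to compound 2 (beyond the scatter) and a number 44.5 percentage points lower from compound 1 to compound 3 (beyond the scatter). Nothing available explains this difference in behaviour.

Going by these compounds, all four compounds carry the sulfur-containing end group, so its own contribution stays open, and an amine or a carboxylic acid on the same carbon would test it. Also open, on these data alone, is how a chain of intermediate length would read in this assay.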